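Cytotoxicity notes: replacing the phenylbutyl chain on the core

This account rests on a few compounds, and the source may have more. Where it says the series, first, only, none or still open, it means among the compounds named here.

Measured so far in an ADME assay on HOS cells (Homo sapiens) for cytotoxicity, read by luminescence and ATP content, with a stated time of 48 h; a lower number here means that less compound is tolerated, a higher number that more compound is tolerated:
- compound 1, `COC(=O)CNc1c(C(=O)NCc2ccc(F)cc2F)c(=O)n(O)c2nc(OC)ccc12`: 12000 nM
- compound 2, `O=C(NCc1ccc(F)cc1F)c1c(O)c2cc(CCCCCO)cnc2n(O)c1=O`: > 250000 nM
- compound 3, `Nc1c(C(=O)NCc2ccc(F)cc2F)c(=O)n(O)c2ncc(CCCCc3ccccc3)cc12`: 13000 nM

Compound 2 gives only a limit of the assay, > 250000 nM, not a number; this is the limit of > 250000 nM in this assay, at which 1 of the 3 values shown sits. Of the two numbers in hand, compound 3 with 13000 nM and compound 1 with 12000 nM lie within the scatter of each other, so no order between them can be read. Compound 3 carries a 4-phenylbutyl chain on the shared core; compound 2, which reached the limit, carries a hydroxyl-terminated chain at a ring carbon instead, but the two also differ elsewhere, so only their two values are noted.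

Compound 4, `Nc1c(C(=O)NCc2ccc(F)cc2F)c(=O)n(O)c2ncc(/C=C/C(=O)NCCO)cc12`, has not yet been measured. It differs from compound 3 in one place: 2-((2-hydroxyethyl)carbamoyl)ethenyl in place of 4-phenylbutyl on an aromatic carbon. Nothing in the data assigns an effect to this exchange. Going by compound 2 reaching the limit > 250000 nM with a polar chain in a comparable position, compound 4 is expected to be tolerated more than compound 3, a step of a 6.2-fold higher number from compound 3 to compound 4 (0.79 log units; beyond the scatter) beyond the scatter, with a fair chance of returning only a limit. The estimate for compound 4 in this assay is 80000 nM, between 20000 nM and 250000 nM.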

Compound 4, half-maximal cytotoxic concentration: > 250000 nM
Compound 4 gave a limit, no number; the forecaster's own chance of this, stated with the estimate: 40%; at least 3.1-fold (0.49 log units) between middle value and limit.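

In this assay, within the data shown here, the exchange of 4-phenylbutyl for 2-((2-hydroxyethyl)carbamoyl)ethenyl on this aromatic carbon gives the first step that changes one place only: an at least 19-fold higher number from compound 3 to compound 4 (1.28 log units; beyond the scatter), a large step. With the rest of the structure unchanged, the cytotoxicity seen for compound 3 cannot belong to the shared core alone, and the group on this carbon decides much of the reading. Compound 4 gives a limit and not a number, so the step has a lower bound only and its full size stays unknown: the limit of > 250000 nM in this assay, at which 2 of the 4 values shown sit.

The exchange removes the aromatic ring and brings in double bonds, hydrogen-bond donors and hydrogen-bond acceptors all at once, and the compounds shown do not tell which of these changes carries the step. A plain alkyl chain without a ring, a saturated chain ending in a hydroxyl, or a chain ending in an amine or a carboxylic acid on the same carbon would begin to separate them, ideally with values that fall below the limit.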